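Working notes: the step from compound 2 to compound 3

This account rests on a few compounds, and the source may have more. Where it says the series, first, only, none or still open, it means among the compounds named here.

Measured in an ADME assay on L6 cells (Rattus norvegicus) for cytotoxicity, read by resazurin assay, with a stated time of 72 h; a lower number here means a stronger inhibitor, a higher number a weaker inhibitor:
- compound 1 `CCc1ccc(C(=O)NC(=O)c2ccccc2O)cc1`: 70 ug/mL
- compound 2 `O=C(NC(=O)c1ccccc1O)c1ccc(OCc2ccccc2)cc1`: 64 ug/mL

The two measured compounds lie within the scatter of each other, so compound 2 at 64 ug/mL stands level with compound 1 and neither marks an end of the range.

The next compound is compound 3 `COC(=O)CCC(=O)Nc1ccc(C(=O)NC(=O)c2ccccc2O)cc1`. Its change from compound 2 is ((2-(methoxycarbonyl)ethyl)carbonyl)amino in place of benzyloxy on an aromatic carbon, para to a large group.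

Among the compounds with values here, one measured step bears on this change. Benzyloxy in place of ethyl on an aromatic carbon gave a 1.1-fold lower number from compound 1 to compound 2 (0.04 log units; within the scatter). Within the data shown here, that is thin evidence, since the entering group has no counterpart among the measured compounds. Even so, the one exchange measured at an aromatic carbon left this assay within the scatter, so no step beyond the scatter is expected here, and no direction is favoured. The expected step is a 1.1-fold higher number from compound 2 to compound 3 (0.04 log units; within the scatter). For compound 3 the estimated value is 70 ug/mL, with an expected range of 35 ug/mL to 130 ug/mL.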

Compound 3, half-maximal inhibitory concentration: > 50 ug/mL
Compound 3: only a limit was reported (the forecaster's own chance of this, stated with the estimate: 25%); the middle value lies beyond the limit too.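

In this assay compound 3 gives > 50 ug/mL, which is a limit and not a number, so the steps from compound 1 and from compound 2 to compound 3 cannot be read. The compounds shown leave open whether ((2-(methoxycarbonyl)ethyl)carbonyl)amino in place of benzyloxy or ethyl moves the number in this assay at all.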